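This account rests on a few compounds, and the source may have more. Where it says the series, first, only, none or still open, it means among the compounds named here.

Compound 3 `NC(=O)CC[C@H](NC(=O)CN(c1nc(Cl)nc2[nH]cnc12)C1CC1)C(=O)OCc1ccccc1` gives 30.8% in a functional assay on the whole organism (Tail, strain ICR) with Mus musculus as the target, in the tail flick test, with a stated time of 30 min, at a dose of 25 umol/kg by the oral route (a lower number here means a weaker effect, a higher number a stronger effect of the compound at the dose given), the lowest of the three measured numbers; compound 2 `CC(C)[C@H](NC(=O)CN(c1nc(Cl)nc2[nH]cnc12)C1CC1)C(=O)OCc1ccccc1` with 33.4% lies within the scatter of it, and only compound 1 `CC[C@H](C)[C@H](NC(=O)CN(c1nc(Cl)nc2[nH]cnc12)C1CC1)C(=O)OCc1ccccc1` with 41.4% stands beyond it. Compound 4 `C[C@@H](O)[C@H](NC(=O)CN(c1nc(Cl)nc2[nH]cnc12)C1CC1)C(=O)OCc1ccccc1` differs from compound 3 in a single place: 1-hydroxyethyl in place of 2-carbamoylethyl on a saturated chain carbon bound to an amide-type nitrogen and a carbonyl carbon. Two measured steps alter the same side chain and bear on this change: a number 10.6 percentage points lower from compound 1 to compound 3 (beyond the scatter) and a number 2.6 percentage points lower from compound 2 to compound 3 (within the scatter). Since every exchange at this carbon shifted the read-out by a modest amount at most, a step of a number 3.2 percentage points higher from compound 3 to compound 4 (within the scatter) is expected for compound 4, with no direction that would clearly pass the scatter. Compound 4 is accordingly estimated at 34%, in a range from 22% to 47%.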

Compound 4, a percentage reported as activity, at one dose (the size of the read-out at that dose, not a potency): 21.9%
The estimate for compound 4 lay 12.1 percentage points above the measured number; measured number below the stated range.
By their numbers in this assay, from the lowest: compounds 4, 3, 2 and 1 (each within the scatter of the next, the first and the last beyond it).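

In this assay, the 1-hydroxyethyl side chain of compound 4 stands clear of both purely carbon side chains, with a number 11.5 percentage points lower from compound 2 to compound 4 (beyond the scatter) and a number 19.5 percentage points lower from compound 1 to compound 4 (beyond the scatter) as its steps, whereas 2-carbamoylethyl had separated only from sec-butyl. Exchanging the two heteroatom-bearing chains gives a number 8.9 percentage points lower from compound 3 to compound 4 (within the scatter) so these two remain unresolved. Going by these compounds alone, the exchanges at this carbon now span a wider range than the earlier compounds showed, though still only a modest one. No evidence available here explains these differences. The compounds shown leave open how an amine, a carboxylic acid or a longer chain at this carbon would read out.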